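The source may hold more compounds than are shown below. What is called first, only, known or untested is meant among the compounds shown, and "the series" means these compounds.

The study concerns four close relatives built on one shared core, each carrying a single small substituent. Compound 1 `Cn1cc(-c2n[nH]c3cc(Br)ccc23)cn1` carries a bromo group, and compound 2 `Cn1cc(-c2n[nH]c3cc(N)ccc23)cn1` carries an amino group in the same place. Compound 3 `Cn1cc(-c2n[nH]c3ccc(N)cc23)cn1` has the same atoms as compound 2, joined differently; the difference between the two cores is not broken down here. Compound 4 `Cn1cc(-c2n[nH]c3ccc(Br)cc23)cn1` is the bromo counterpart of compound 3.

In an assay on isolated protein for inhibition of tyrosine-protein kinase receptor UFO (Homo sapiens), with a stated time of 1.5 h (on this read-out higher numbers stand for weaker inhibition and lower numbers for stronger inhibition), compound 1 gives 950 nM. Compound 2 gives 28800 nM in this assay, and compound 3 gives 8910 nM, which places compound 3 between the other two, nearer to compound 2 than to compound 1. The change from compound 2 to compound 1 is bromo in place of amino on an aromatic carbon and it produced a 30-fold lower number from compound 2 to compound 1 (1.48 log units; beyond the scatter).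

Compound 4 has not yet been measured. Its change from compound 3 is bromo in place of amino on an aromatic carbon, the same change as from compound 2 to compound 1, occurring twice among these compounds. The step expected from compound 3 to compound 4 in this assay is a 20-fold lower number from compound 3 to compound 4 (1.30 log units; beyond the scatter), set beside the measured one; that expectation rests on compound 2 and compound 1 and their step of a 30-fold lower number from compound 2 to compound 1 (1.48 log units; beyond the scatter). Since the cores of compound 3 and compound 2 are not the same, the expected step is taken somewhat smaller than the measured one. Compound 4 is estimated at 450 nM, with a range from 120 nM to 2000 nM.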

Compound 4, half-maximal inhibitory concentration: 1540 nM
The estimate for compound 4 lay 3.4-fold (0.53 log units) below the measured number, and the stated range covers the measured number.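

Bromo in place of amino on an aromatic carbon lowers the number again in this assay, here with a 5.8-fold lower number from compound 3 to compound 4 (0.76 log units; beyond the scatter), so the direction of the change is the same on the core of compound 2 and on the core of compound 3. The size of the step, however, does not carry over unchanged from one core to the other: the same change on two cores in this assay, a 30-fold lower number (1.48 log units; beyond the scatter) from compound 2 to compound 1 and a 5.8-fold lower number (0.76 log units; beyond the scatter) from compound 3 to compound 4, 5.2-fold (0.72 log units) apart, beyond the scatter of two such steps. Going by these compounds alone, with only two pairs, this shows that the change favoured the bromo compound on both cores, but it does not show what sets the size of the step, nor does it establish that the same direction or either size would hold on any further core.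

The compounds shown leave open how other groups would compare with bromo and amino in these two places, such as a chloro group, a methoxy group, a nitrile or a carboxylic acid. They also leave open whether a larger substituent, such as a longer chain or a substituted amine, would widen or narrow the difference between the two cores.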